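The source may hold more compounds than are shown below. What is called first, only, known or untested is meant among the compounds shown, and "the series" means these compounds.

Measured so far:
- Compound 1 `CNc1ncnc2c1c(-c1ccsc1)cn2[C@@H]1O[C@H](CO)[C@@H](O)[C@H]1O`: in a functional assay on HeLa S3 cells (Homo sapiens) for antiproliferative activity, read by XTT assay, with a stated time of 72 h (a lower number here means a stronger inhibitor, a higher number a weaker inhibitor), compound 1 gives > 20000 nM, a limit of the assay.
- Compound 2 `CNc1ncnc2c1c(-c1cccs1)cn2[C@@H]1O[C@H](CO)[C@@H](O)[C@H]1O`: compound 2 gives > 20000 nM, again a limit.
- Compound 3 `CNc1ncnc2c1c(-c1cc3ccccc3o1)cn2[C@@H]1O[C@H](CO)[C@@H](O)[C@H]1O`: compound 3 gives > 20000 nM, again a limit.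

Compound 1 therefore stands only at the limit of > 20000 nM in this assay, at which 3 of the 3 values shown sit, as do the other two. Compound 4 `CSc1ncnc2c1c(-c1ccsc1)cn2[C@@H]1O[C@H](CO)[C@@H](O)[C@H]1O` differs from compound 1 in one place: methylsulfanyl in place of methylamino on an aromatic carbon. The measured steps a step that the two limits leave unreadable from compound 1 to compound 2, a step that the two limits leave unreadable from compound 1 to compound 3 and a step that the two limits leave unreadable from compound 2 to compound 3 all concern the aryl group and none of them is readable, so nothing measured speaks to the methylsulfanyl change. No step beyond the scatter is expected from compound 1 to compound 4; the expected step is a number no higher from compound 1 to compound 4 (the limit leaves the size open). Compound 4 is estimated at 20000 nM, in the range 8000 nM to 60000 nM, most likely reported as a limit again.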

Compound 4, half-maximal inhibitory concentration: > 20000 nM
Compound 4: no number, only a limit (the forecaster's own chance of this, stated with the estimate: 80%); the middle value lies on the limit itself.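

In this assay compound 4 gives > 20000 nM, a limit and not a number, so the step from compound 1 to compound 4 cannot be read. The compounds shown leave open the size and direction of every change, aryl or methylsulfanyl.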